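The source may report more compounds than this note shows. Statements on the series, on what has been measured and on what is new or still open speak of the compounds shown alone.

Measured compounds:
compound 1 `CC(O)c1ccc(C(=O)N[C@@H](C)Cn2ccc(-c3ccc(C#N)c(Cl)c3)n2)cc1`: > 30000 nM
compound 2 `C[C@@H](Cn1ccc(-c2ccc(C#N)c(Cl)c2)n1)NS(=O)(=O)c1cccnc1`: "not determined" (no result reported)

In an ADME assay on L02 cells (Homo sapiens) for cytotoxicity, read by CCK-8 assay, with a stated time of 6 days (on this read-out lower numbers stand for stronger inhibition and higher numbers for weaker inhibition), compound 1 gives > 30000 nM, which is a limit of the assay and not a number. For the measured compounds named here, the one value of the series sits at this limit (the limit of > 30000 nM in this assay, at which 1 of the 2 values shown sits). For compound 2 this assay records "not determined" (no result reported), so compound 2 stands without a number of its own in this assay.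

Compound 3 `C[C@@H](Cn1ccc(-c2ccc(C#N)c(Cl)c2)n1)Nc1ncnc2nc[nH]c12` differs from compound 2 by a group of 9 heavy atoms (5 carbon, 4 nitrogen; one five-membered aromatic ring with 2 hetero atoms, one six-membered aromatic ring with 2 hetero atoms) in place of a group of 9 heavy atoms (5 carbon, 1 nitrogen, 2 oxygen, 1 sulfur; one six-membered aromatic ring with 1 hetero atom), on an amine nitrogen. It is not yet measured in this assay. Going by the values given here, no measured step between two compounds exists, so the size of the step from compound 2 to compound 3 cannot be drawn from the data; with the only value of the series sitting at the limit (the limit of > 30000 nM in this assay, at which 1 of the 2 values shown sits), a step beyond the scatter is not expected in either direction.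

Compound 3 is therefore expected to give about 30000 nM in this assay, within 10000 nM to 100000 nM.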

Compound 3, half-maximal inhibitory concentration: 27900 nM
Beside the measured number, compound 3's estimate is 1.1-fold (0.03 log units) above it, and the stated range covers the measured number.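

In this assay, no step can be read from the result for compound 3: compound 2 carries no number of its own. The compounds shown leave open how far a change of the group on the amine nitrogen shifts the value in this assay.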